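Swapping an Ethynyl for an Acetylphenyl Group

A few compounds are considered here, and "the series" means these few. Any claim that something is new, unique, unknown or untested is made for them only; others in the source may bear on it.

Measured compounds:
compound 1 `O=C(CCc1cccc2c1B(O)OC2)Nc1ccc(F)cc1`: 650 nM
compound 2 `C#Cc1cccc(NC(=O)CCc2cccc3c2B(O)OC3)c1`: 3600 nM

Both compounds share one core and differ only in the group carried on the aromatic ring of the amide. In a functional assay on HCT-116 cells (Homo sapiens) for antiproliferative activity, read by MTT assay, with a stated time of 72 h (on this read-out lower numbers stand for stronger inhibition and higher numbers for weaker inhibition), compound 1 gives 650 nM and compound 2 gives 3600 nM. Compound 2 therefore stands at the higher of the two numbers, and its distance from compound 1 lies beyond the usual scatter of repeated measurements.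

Compound 3 `CC(=O)c1cccc(-c2cccc(NC(=O)CCc3cccc4c3B(O)OC4)c2)c1` has not yet been measured. Compared with compound 2 it carries 3-acetylphenyl in place of ethynyl on an aromatic carbon. For the measured compounds named here, no measured pair shows a change of this kind, so its effect on the numbers is unknown. A step of moderate size in this assay is expected, without a firm direction. The expected step is a 1.8-fold lower number from compound 2 to compound 3 (0.26 log units; within the scatter). For compound 3 the estimated value is 2000 nM, with a likely range from 500 nM to 8000 nM.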

Compound 3, half-maximal inhibitory concentration: 86 nM
Compound 3: the middle estimate sits 23-fold (1.37 log units) above what was measured; measured number outside the range, below it.
By their numbers in this assay, from the lowest: compound 3; then compound 1; then compound 2.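

In this assay the exchange of ethynyl for 3-acetylphenyl gives a 42-fold lower number from compound 2 to compound 3 (1.62 log units; beyond the scatter) and so shows that this place on the aromatic ring can hold a much larger group than ethynyl. For the compounds shown here, the larger group, with its own six-membered aromatic ring, goes with a far lower number here, whereas the earlier compounds offered no step at this place at all. Nothing measured here explains why the number falls.

The change adds an aromatic ring and an acetyl group together, so the compounds shown cannot tell which of the two parts accounts for the step. Going by these compounds, whether a plain phenyl group, or a phenyl ring carrying an amine or a carboxylic acid in place of the acetyl, would give a similar number remains open.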